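This account rests on a few compounds, and the source may have more. Where it says the series, first, only, none or still open, it means among the compounds named here.

Measured compounds:
- compound 1 `CSc1nc(NCc2ccc(-c3ccccn3)cc2)c2[nH]nc(C(C)C)c2n1`: 783 nM
- compound 2 `CC(C)c1n[nH]c2c(NCc3ccc(-c4ccccn4)cc3)nc(SCCN)nc12`: 22 nM
- compound 3 `CC(C)c1n[nH]c2c(NCc3ccc(-c4ccccn4)cc3)nc(SCCNC(N)=O)nc12`: 240 nM

In a functional assay on HT cells (Homo sapiens) for antiproliferative activity, read by fluorescence, with a stated time of 72 h (on this read-out higher numbers stand for weaker inhibition of growth and lower numbers for stronger inhibition of growth), compound 1 gives the highest of the three numbers. The nearest is compound 3, a modest step: a 3.3-fold lower number from compound 1 to compound 3 (0.51 log units; beyond the scatter). The furthest is compound 2, a large step: a 36-fold lower number from compound 1 to compound 2 (1.55 log units; beyond the scatter).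

Compound 4 `CSCCSc1nc(NCc2ccc(-c3ccccn3)cc2)c2[nH]nc(C(C)C)c2n1` is unmeasured. It differs from compound 1 as follows: (methylsulfanyl)methyl in place of hydrogen on a saturated chain carbon bound to a sulfur. The steps from compound 1 to compound 2 and to compound 3 bear on this, both at the same place, but the entering group here carries 0 hydrogen-bond donors and no net charge, unlike either. A small lowering in this assay is expected, near the scatter: a 1.7-fold lower number from compound 1 to compound 4 (0.24 log units; within the scatter). Compound 4 is estimated at 450 nM, range 150 nM to 1300 nM.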

Compound 4, concentration for 50% growth inhibition: 975 nM
For compound 4 the middle estimate is 2.2-fold (0.34 log units) below the measured one; the measured number falls inside the stated range.
By their numbers in this assay, from the lowest: compound 2; then compound 3; then compounds 1 and 4 (each within the scatter of the next).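

In this assay, (methylsulfanyl)methyl on the saturated chain carbon bound to a sulfur gives no change beyond the scatter (a 1.2-fold higher number from compound 1 to compound 4 (0.10 log units; within the scatter)), so the added chain without an amino or ureido group does not match the lower numbers of the other two compounds. Methylsulfanyl in place of ureido gives (a 4.1-fold higher number from compound 3 to compound 4 (0.61 log units; beyond the scatter)) and methylsulfanyl in place of amino gives (a 44-fold higher number from compound 2 to compound 4 (1.65 log units; beyond the scatter)), so among these compounds the group two bonds along the chain from a sulfur sets the number. Nothing available explains these differences. Going by these compounds, whether a methylated amine, a hydroxyl or a carboxylic acid there would track the amino result remains open. A longer chain carrying the amine is also untested in the compounds shown.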